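The compounds below may be only part of what the source reports. "The series", "measured", "known", "first", "only" and "open" are said of these compounds alone.

For the measured compounds named here, compound 3 `COc1ccc(O)c(CCCNC(C)=O)c1` sits second highest of the three numbers so far in an assay on CHO cells for displacement of a labelled ligand from melatonin receptor type 1A (Homo sapiens), read by scintillation counting, with a stated time of 60 min (a lower number here means a stronger inhibitor, a higher number a weaker inhibitor), where compound 3 gives 379 nM. Going by the values given here, its parent, compound 1 `COc1cccc(CCCNC(C)=O)c1`, gives 23.3 nM in this assay, and the single change, a 16-fold higher number from compound 1 to compound 3 (1.21 log units; beyond the scatter), is the only measured step in the set. Among the compounds with values here, compound 2 `CCCC(=O)NCCCc1cc(OC)ccc1OCc1ccccc1` carries an alkylated oxygen at that same place together with a longer amide, and in this assay compound 2 gives 1170 nM; no single step connects it to compound 3, so its value is only a pointer.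

Compound 4 `CCCOc1ccc(OC)cc1CCCNC(C)=O` differs from compound 3 by propyl in place of hydrogen on an oxygen on an aromatic ring. Within the data shown here, no measured step covers this change directly. The weak number of compound 2, 1170 nM, is the nearest hint that capping this oxygen does not recover the potency of compound 1, but compound 2 also differs in its amide. Compound 4 is therefore expected to change little or to weaken modestly, a step of a 1.2-fold higher number from compound 3 to compound 4 (0.07 log units; within the scatter), with an estimate of 450 nM and a range from 120 nM to 1800 nM.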

Compound 4, inhibition constant: 400 nM
The estimate for compound 4 lay 1.1-fold (0.05 log units) above the measured number; low and high end bracket the measured number.
By their numbers in this assay, from the lowest: compound 1; then compounds 3 and 4 (each within the scatter of the next); then compound 2.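

In this assay, propyl on the oxygen on the aromatic ring gives no change that can be told from the scatter (a 1.1-fold higher number from compound 3 to compound 4 (0.02 log units; within the scatter)). Hydroxy and propoxy at this place therefore read alike, and the large loss against the parent with hydrogen on that aromatic carbon holds for propoxy as well (a 17-fold higher number from compound 1 to compound 4 (1.23 log units; beyond the scatter)). No evidence is at hand that bears on why these two groups give such similar numbers.

Going by these compounds, with this amide, only hydrogen, hydroxy and propoxy can be compared at this place, so it remains open whether any other group there would come back towards compound 1. A fluorine, an amine or a shorter methoxy on that aromatic carbon would test whether the loss belongs to any group at this place or only to these two.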